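This account rests on a few compounds, and the source may have more. Where it says the series, first, only, none or still open, it means among the compounds named here.

Three compounds have been measured in a functional assay on L1210 cells (Mus musculus), with a stated time of 12 days; on this read-out lower numbers stand for lower potency and higher numbers for higher potency (the scale is a negative logarithm):

compound 1, `CC1=C(N2CC2)C(=O)C(CC(C)OC(N)=O)=C(N2CC2)C1=O`, giving 6.14;
compound 2, `CN(C)C(=O)OCCC1=C(N2CC2)C(=O)C(CCOC(=O)N(C)C)=C(N2CC2)C1=O`, giving 5.16;
compound 3, `CCC1=C(N2CC2)C(=O)C(CC)=C(N2CC2)C1=O`, giving 5.46.

Compound 1 stands highest of the three numbers. Its nearest neighbour is compound 3, whose value lies below it by a margin beyond the usual scatter, and the furthest is compound 2, lower still and also beyond the scatter. Compound 1 is therefore the most potent of the measured set in this assay.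

The step under consideration leads from compound 1 to compound 4, `COC(CO)C1=C(N2CC2)C(=O)C(C)=C(N2CC2)C1=O`, which has not yet been tested. The change is a group of 5 heavy atoms (3 carbon, 2 oxygen; no ring) in place of a group of 7 heavy atoms (4 carbon, 1 nitrogen, 2 oxygen; no ring), on a double-bonded ring carbon. The 2-hydroxy-1-methoxyethyl group enters on a double-bonded ring carbon of the six-membered non-aromatic ring of carbon only, next to the ring atom that bears an aziridin-1-yl group.

Among the measured compounds shown here, no pair of measured compounds differing in a single place is available, so the size of this step cannot be read from a matched example. What the data do show is that compound 3, which carries no carbamate at all, gives 5.46, well below compound 1. On that basis a downward step beyond the scatter is expected, and the estimate for compound 4 in this assay is 5.5, with a range from 4.9 to 6.1. This expected step corresponds to a number 0.64 log units lower from compound 1 to compound 4 (beyond the scatter).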

Compound 4, logarithm of the reciprocal of the active concentration, log(1/C): 6.9
Compound 4: the middle estimate sits 1.40 log units below what was measured, and the stated range ends below it.
By their numbers in this assay, from the lowest: compounds 2 and 3 (each within the scatter of the next); then compound 1; then compound 4.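

In this assay, putting 2-hydroxy-1-methoxyethyl in place of the group of 7 heavy atoms gives a number 0.76 log units higher from compound 1 to compound 4 (beyond the scatter), on a double-bonded ring carbon next to the ring atom that bears an aziridin-1-yl group. The earlier compounds shown here could not show this, as none of them formed a pair differing in one place; this step shows that the carbamate of compound 1 is not needed at this position to reach a high number on this read-out, and that a group with fewer heavy atoms and no nitrogen can stand there with a gain beyond the scatter. No measurement is at hand that explains the size or direction of this step.

On these data alone, it remains open which part of the entering group goes with the gain, and whether a plain 2-hydroxyethyl or a 1-methoxyethyl chain at this position would match compound 4 at 6.9 in this assay. As far as these compounds go, it is equally open how an amine or a carboxylic acid in place of the hydroxyl, or a longer chain carrying the same hydroxyl and methoxy groups, would read in this assay.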